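Tail flick series: amide chain to isopropyl exchange

The source may hold more compounds than are shown below. What is called first, only, known or untested is meant among the compounds shown, and "the series" means these compounds.

Measured compounds:
compound 1 `NC(=O)C[C@H](NC(=O)CN(c1nc(Cl)nc2[nH]cnc12)C1CC1)C(=O)O` — 7.51%
compound 2 `CC(C)[C@H](NC(=O)CN(c1nc(Cl)nc2[nH]cnc12)C1CC1)C(=O)O` — 7.86%
compound 3 `NC(=O)CC[C@H](NC(=O)CN(c1nc(Cl)nc2[nH]cnc12)C1CC1)C(=O)OCc1ccccc1` — 31.1%

In a functional assay on the whole organism (Tail, strain ICR) with Mus musculus as the target, in the tail flick test, with a stated time of 150 min, at a dose of 25 umol/kg by the oral route (on this read-out higher numbers stand for a stronger effect at the one dose given and lower numbers for a weaker effect), compound 1 gives 7.51%. Compound 2 gives 7.86% in this assay. The change between them is isopropyl in place of carbamoylmethyl on a saturated chain carbon bound to an amide-type nitrogen and a carbonyl carbon, and the step is a number 0.4 percentage points higher from compound 1 to compound 2 (within the scatter). Compound 3 gives 31.1% in this assay, beyond the scatter of both compound 1 and compound 2; how its core differs from the core of compound 1 is not broken down here.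

Compound 4 `CC(C)C[C@H](NC(=O)CN(c1nc(Cl)nc2[nH]cnc12)C1CC1)C(=O)OCc1ccccc1` has not been measured. It differs from compound 3 by isopropyl in place of carbamoylmethyl on a saturated chain carbon, two bonds along the chain from an amide-type nitrogen and a carbonyl carbon. Within the data shown here, this is the same kind of change as the one from compound 1 to compound 2, but not the same: there the group sits on a saturated chain carbon bound to an amide-type nitrogen and a carbonyl carbon, here on a saturated chain carbon two bonds along the chain from an amide-type nitrogen and a carbonyl carbon. Because the earlier step was a number 0.4 percentage points higher from compound 1 to compound 2 (within the scatter), the step from compound 3 to compound 4 is expected to be small, about a number 0.1 percentage points lower from compound 3 to compound 4 (within the scatter). Compound 4 is therefore estimated at 31% in this assay, with a range of 17% to 45%.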

Compound 4, a percentage reported as activity, at one dose (the size of the read-out at that dose, not a potency): 5.26%
The estimate for compound 4 lay 25.7 percentage points above the measured number; the whole stated range lies above it.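

In this assay, the exchange of carbamoylmethyl for isopropyl does not carry over from one core to the other, and on the core of compound 3 it costs most of the effect at the one dose given, a number 25.8 percentage points lower from compound 3 to compound 4 (beyond the scatter). Set side by side, the two steps differ: the same change on two cores in this assay, a number 0.4 percentage points higher (within the scatter) from compound 1 to compound 2 and a number 25.8 percentage points lower (beyond the scatter) from compound 3 to compound 4, 26.2 percentage points apart, beyond the scatter of two such steps. The step on the core of compound 1 therefore gives no usable guide to the core of compound 3, but this single pair of steps does not show what separates them, as the cores differ and the group also sits at a different place on the chain.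

Going by these compounds, it remains open whether an amine or a carboxylic acid in place of the carbamoylmethyl on the core of compound 3 would hold the read-out near that of compound 3 or drop it towards that of compound 4. On these data alone, a longer chain ending in a carbamoyl group is also open on both cores, as is any read-out at a second dose or time.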